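Imidazole Diaryl Urea With a Substituted Trifluoromethylphenyl Group

The source may report more compounds than this note shows. Statements on the series, on what has been measured and on what is new or still open speak of the compounds shown alone.

Compound 3 `O=C(Nc1ccc(Cl)cc1)Nc1ccc(Oc2ccc(-c3ncc[nH]3)cc2)cc1` gives 8.86% in a functional assay on A549 cells (Homo sapiens) for inhibition, read by MTT assay and WST assay, with a stated time of 72 h, tested at 10 uM (a lower number here means less inhibition of growth, a higher number more inhibition of growth at the concentration tested), the lowest of the three numbers measured here. Its nearest neighbour is compound 1 `O=C(Nc1ccc(Cl)cc1)Nc1ccc(Oc2ccc(-c3nccs3)cc2)cc1`, which gives 17.7%; the two differ only in that compound 3 carries a 1H-imidazol-2-yl in place of the 1,3-thiazol-2-yl, and the step of a number 8.8 percentage points lower from compound 1 to compound 3 (within the scatter) lies within the scatter. Compound 2 `O=C(Nc1ccc(Oc2ccc(-c3nccs3)cc2)cc1)Nc1cc(Br)cc(C(F)(F)F)c1` gives 81.7%, and the step of a number 64 percentage points higher from compound 1 to compound 2 (beyond the scatter) is large and well beyond the scatter.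

Compound 4 `O=C(Nc1ccc(Oc2ccc(-c3ncc[nH]3)cc2)cc1)Nc1cc(C(F)(F)F)ccc1Cl` is not yet measured. It differs from compound 3 in one place: 2-chloro-5-(trifluoromethyl)phenyl in place of 4-chlorophenyl on an amide-type nitrogen. Within the data shown here, the step that bears on this is the one from compound 1 to compound 2, where the 4-chlorophenyl on the amide-type nitrogen also gave way to a phenyl carrying a halogen and a trifluoromethyl group, and the number rose by a number 64 percentage points higher from compound 1 to compound 2 (beyond the scatter). The entering group in compound 4 is not the same as in compound 2, so the change is expected to be large and upward, but with a wider range. Compound 4 is therefore estimated to give 55% in this assay, within 25% to 85%, an expected step of a number 46.1 percentage points higher from compound 3 to compound 4 (beyond the scatter).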

Compound 4, percent growth inhibition at one concentration: 22.3%
The estimate for compound 4 lay 32.7 percentage points above the measured number; the whole stated range lies above it.
By their numbers in this assay, from the lowest: compounds 3, 1 and 4 (each within the scatter of the next, the first and the last beyond it); then compound 2.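

In this assay, the swap of 4-chlorophenyl for 2-chloro-5-(trifluoromethyl)phenyl on the amide-type nitrogen gives a number 13.4 percentage points higher from compound 3 to compound 4 (beyond the scatter), so this position also responds when the shared core carries 1H-imidazol-2-yl, though the step is only modest. Among these compounds, until now the position had been seen only with 1,3-thiazol-2-yl, where 3-bromo-5-(trifluoromethyl)phenyl gave a number 64 percentage points higher from compound 1 to compound 2 (beyond the scatter), and the new result shows that a phenyl with a halogen and a trifluoromethyl group does not bring a large step in every case. Nothing available explains the difference in size between the two steps.

Compound 2 and compound 4 differ in two places, so the compounds shown leave open whether the size of the step follows the 1H-imidazol-2-yl, the 1,3-thiazol-2-yl or the particular substituted phenyl on the nitrogen. They also leave open how the position would respond to a phenyl carrying an amine or a carboxylic acid instead of a halogen and a trifluoromethyl group.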